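Compound 3: methyl in place of hydroxy

The source may report more compounds than this note shows. Statements on the series, on what has been measured and on what is new or still open speak of the compounds shown alone.

In a functional assay on HL-60 cells (Homo sapiens) for cytotoxicity, read by MTT assay, with a stated time of 48 h (a higher number here means a weaker inhibitor, a lower number a stronger inhibitor), compound 1 (`Oc1ccc(Nc2nc(-c3cccc(F)c3)nc3ccc(F)cc23)cc1`) gives > 50000 nM, which is a limit and not a number. Among the measured compounds shown here, compound 2 (`Oc1ccccc1Nc1nc(-c2cccc(F)c2)nc2ccc(F)cc12`) gives 44400 nM, the only actual number so far. For the measured compounds named here, the sole measured step is an at least 1.1-fold lower number from compound 1 to compound 2 (0.05 log units; that floor lies within the scatter), for 2-hydroxyphenyl in place of 4-hydroxyphenyl. Compound 3 (`Cc1ccccc1Nc1nc(-c2cccc(F)c2)nc2ccc(F)cc12`) has methyl in place of hydroxy on an aromatic carbon, ortho to a large group: methyl in place of hydroxy on an aromatic carbon. The measured step does not test this replacement, so no change beyond the scatter is expected, and the expected step is a 1.5-fold lower number from compound 2 to compound 3 (0.17 log units; within the scatter). Compound 3 is estimated at 30000 nM, with a range of 9000 nM to 50000 nM.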

Compound 3, half-maximal inhibitory concentration: > 50000 nM
Compound 3 was reported as a limit; the forecaster's own chance of this, stated with the estimate: 30%; at least 1.6-fold (0.22 log units) between middle value and limit.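

In this assay, methyl in place of hydroxy on an aromatic carbon, ortho to a large group, is now tested directly and gives an at least 1.1-fold higher number from compound 2 to compound 3 (0.05 log units; that floor lies within the scatter); the true size of this change stays hidden, since the value for compound 3 is a limit. The step from compound 1 to compound 3 cannot be read. The series now rests mostly on a limit rather than a number: the limit of > 50000 nM in this assay, at which 2 of the 3 values shown sit.

As far as these compounds go, whether an amine or a methoxy group in this place would give a number clearly lower than that of compound 2 remains open.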